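A few compounds are considered here, and "the series" means these few. Any claim that something is new, unique, unknown or untested is made for them only; others in the source may bear on it.

Within the data shown here, compound 1 `[N-]=[N+]=Nc1cc(Cl)ncc1Cn1ccsc1=N` and compound 2 `N=c1sccn1Cc1ccc(Cl)nc1` are the two measured members. In an assay on M10 cells (Gallus gallus) for binding affinity to Neuronal acetylcholine receptor; alpha4/beta2 (Homo sapiens) (on this read-out lower numbers stand for stronger inhibition and higher numbers for weaker inhibition), compound 1 gives 110 nM and stands highest of the two numbers; compound 2 gives 0.39 nM. The single step shown, a 280-fold lower number from compound 1 to compound 2 (2.45 log units; beyond the scatter), is a hydrogen in place of azido on an aromatic carbon. Compound 3 `[N-]=[N+]=Nc1ccncc1Cn1ccsc1=N` differs from compound 1 by hydrogen in place of chloro on an aromatic carbon. Among the measured compounds shown here, no measured step covers this change, so the size to expect in this assay is uncertain; a modest rise is expected, a 3.2-fold higher number from compound 1 to compound 3 (0.50 log units; beyond the scatter). Compound 3 is estimated at 350 nM, with a range of 60 nM to 2000 nM.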

Compound 3, inhibition constant: 820 nM
Compound 3: the middle estimate sits 2.3-fold (0.37 log units) below what was measured; measured number inside the range.
By their numbers in this assay, from the lowest: compound 2; then compound 1; then compound 3.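

In this assay, hydrogen in place of the chloro next to the ring nitrogen gives a 7.5-fold higher number from compound 1 to compound 3 (0.87 log units; beyond the scatter), so chloro at this position goes with the lower number while the azido group stays in place. This step is smaller than a 280-fold lower number from compound 1 to compound 2 (2.45 log units; beyond the scatter), yet it lies beyond the scatter. Nothing available explains the difference between chloro and hydrogen here.

On these data alone, whether the same step holds in the absence of the azido group remains open. So does the effect of fluoro, bromo, methyl or an amine at this position.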